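Swapping the amidine for an oxime on a shared core

The source may report more compounds than this note shows. Statements on the series, on what has been measured and on what is new or still open speak of the compounds shown alone.

Three compounds share one core and differ only in the group on the aromatic carbon para to a large group. Compound 1 `CCOc1ccc(Br)cc1-c1cc(Nc2ccc(B(O)O)cc2)nc(N)n1` carries a boronic acid and in an assay on Sf9 cells for inhibition of 1-acyl-sn-glycerol-3-phosphate acyltransferase beta (Homo sapiens) (on this read-out lower numbers stand for stronger inhibition and higher numbers for weaker inhibition), compound 1 gives 91 nM. Compound 2 `CCOc1ccc(Br)cc1-c1cc(Nc2ccc(C#N)cc2)nc(N)n1` carries a nitrile, and in this assay compound 2 gives 17 nM. Compound 3 `CCOc1ccc(Br)cc1-c1cc(Nc2ccc(C(=N)N)cc2)nc(N)n1` carries an amidine, and in this assay compound 3 reaches only a limit, > 5000 nM; the limit of > 5000 nM in this assay, at which 1 of the 3 values shown sits, marks where this value sits. The steps into the amidine were both large: an at least 54-fold higher number from compound 1 to compound 3 (1.73 log units; beyond the scatter) and an at least 290-fold higher number from compound 2 to compound 3 (2.46 log units; beyond the scatter). The step from compound 1 to compound 2 was smaller: a 5.4-fold lower number from compound 1 to compound 2 (0.73 log units; beyond the scatter).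

Compound 4 `CCOc1ccc(Br)cc1-c1cc(Nc2ccc(/C(C)=N\O)cc2)nc(N)n1` arises from compound 3 by the change (a group of 4 heavy atoms (2 carbon, 1 nitrogen, 1 oxygen; no ring) in place of a group of 3 heavy atoms (1 carbon, 2 nitrogen; no ring), on an aromatic carbon). Both measured steps that removed or introduced the amidine were large, so leaving it is expected to lower the number strongly: the expected step is an at least 41-fold lower number from compound 3 to compound 4 (1.61 log units; beyond the scatter). Compound 4 is therefore estimated to give about 120 nM in this assay, within the range 20 nM to 1000 nM.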

Compound 4, half-maximal inhibitory concentration: 84 nM
For compound 4 the middle estimate is 1.4-fold (0.15 log units) above the measured one, within the range that was stated.
By their numbers in this assay, from the lowest: compound 2; then compounds 4 and 1 (each within the scatter of the next). At a limit, above all of these: compound 3.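

The oxime-bearing compound shows that this aromatic carbon does not reject every group that replaces the nitrile or the boronic acid, since moving away from the amidine gives an at least 59-fold lower number from compound 3 to compound 4 (1.77 log units; beyond the scatter). That step has only a lower bound, and compound 3 is a limit rather than a measured number: the limit of > 5000 nM in this assay, at which 1 of the 4 values shown sits. The nitrile still keeps an edge over the oxime, with a 4.9-fold higher number from compound 2 to compound 4 (0.69 log units; beyond the scatter), while the oxime and the boronic acid cannot be told apart, with a 1.1-fold lower number from compound 1 to compound 4 (0.03 log units; within the scatter).

On these data alone, what separates the amidine from the other three groups remains unknown. An amine or a carboxylic acid on this aromatic carbon would test whether the poor result is peculiar to the amidine, and an oxime without its methyl would show whether that methyl matters.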